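The source may hold more compounds than are shown below. What is called first, only, known or untested is meant among the compounds shown, and "the series" means these compounds.

Measured compounds:
compound 1 `COc1ccc(C(=O)/C=C/c2ccc(OCc3cn(Cc4cccc(F)c4)nn3)cc2)cc1`, 56%
compound 2 `O=C(/C=C/c1ccc(OCc2cn(Cc3ccccc3Br)nn2)cc1)c1ccc([N+](=O)[O-])cc1`, 42%

In a functional assay on A549 cells (Homo sapiens) for inhibition, read by MTT assay, with a stated time of 48 h, tested at 10 uM (a lower number here means less inhibition of growth, a higher number more inhibition of growth at the concentration tested), compound 2 gives 42%, the lower of the two numbers shown. Compound 1 gives 56% in this assay, and the gap between the two lies beyond the scatter; since these two compounds differ in more than one place, their values show only that. Compound 3 `O=C(/C=C/c1ccc(OCc2cn(Cc3cccc(F)c3)nn2)cc1)c1ccc([N+](=O)[O-])cc1` differs from compound 2 in a single respect: 3-fluorophenyl in place of 2-bromophenyl on a saturated chain carbon bound to an aromatic nitrogen. Among the measured compounds shown here, no step of exactly this kind has been measured. The step expected from this change in this assay is a number 6 percentage points higher from compound 2 to compound 3 (within the scatter), small and likely not beyond the scatter. Compound 3 is estimated at 48%, with a range from 35% to 62%.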

Compound 3, percent growth inhibition at one concentration: 33%
For compound 3 the middle estimate is 15 percentage points above the measured one; measured number below the stated range.
By their numbers in this assay, from the lowest: compounds 3 and 2 (each within the scatter of the next); then compound 1.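

In this assay, 3-fluorophenyl in place of 2-bromophenyl on a saturated chain carbon bound to an aromatic nitrogen gives a number 9 percentage points lower from compound 2 to compound 3 (within the scatter), so with the nitro group present, this position shows no difference that can be told from scatter. Nitro in place of methoxy on an aromatic carbon, with the 3-fluorophenyl held fixed, gives a number 23 percentage points lower from compound 1 to compound 3 (beyond the scatter), a single-place step that the first two compounds could not provide. Nothing given here explains the size of either step. As far as these compounds go, it remains open how an amine on that aromatic carbon would read, and whether the 2-bromophenyl behaves the same way alongside methoxy.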